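Swapping the aryl on the ring nitrogen of compound 3

The source may report more compounds than this note shows. Statements on the series, on what has been measured and on what is new or still open speak of the compounds shown alone.

Three analogues sharing one core have been tested in a functional assay on MCF7 cells (Homo sapiens) for cytotoxicity, read by MTT assay, with a stated time of 72 h; on this read-out lower numbers stand for stronger inhibition and higher numbers for weaker inhibition. Compound 1 `CNC(=O)c1cc(Oc2ccc(NC(=O)c3nn(-c4ccccc4F)c(=O)cc3C)cc2F)ccn1` reaches only the assay limit > 40000 nM there. Compound 2 `Cc1cc(=O)n(-c2ccccc2C(F)(F)F)nc1C(=O)Nc1ccc(Oc2ncnc3ccsc23)cc1` gives 5550 nM in this assay, and compound 3 `Cc1cc(=O)n(-c2ccc(Br)cc2F)nc1C(=O)Nc1ccc(Oc2ncnc3ccsc23)cc1` gives 9360 nM, the highest of the two numbers shown. Compound 4 `Cc1cc(=O)n(-c2ccccc2OC(F)(F)F)nc1C(=O)Nc1ccc(Oc2ncnc3ccsc23)cc1` carries the change (2-(trifluoromethoxy)phenyl in place of 4-bromo-2-fluorophenyl on an aromatic nitrogen). For the measured compounds named here, the only measured step that bears on this change is a 1.7-fold higher number from compound 2 to compound 3 (0.23 log units; within the scatter), likewise an exchange of the aryl group on the aromatic nitrogen, and it stayed within the scatter. Compound 4 is therefore expected to sit near compound 3, with a step of a 1.3-fold lower number from compound 3 to compound 4 (0.13 log units; within the scatter) that is not expected to go beyond the scatter. Compound 4 is estimated at 7000 nM, with a range from 2500 nM to 25000 nM.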

Compound 4, half-maximal inhibitory concentration: 23800 nM
The estimate for compound 4 lay 3.4-fold (0.53 log units) below the measured number; the range from low to high includes it.
By their numbers in this assay, from the lowest: compounds 2 and 3 (each within the scatter of the next); then compound 4. At a limit, above all of these: compound 1.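

In this assay, the aryl on the aromatic nitrogen proves able to shift the number beyond the scatter: the exchange gives a 2.5-fold higher number from compound 3 to compound 4 (0.41 log units; beyond the scatter). The smaller exchange of trifluoromethyl for trifluoromethyloxy's close form is not needed to see this, since trifluoromethoxy in place of trifluoromethyl on an aromatic carbon alone gives a 4.3-fold higher number from compound 2 to compound 4 (0.63 log units; beyond the scatter). Nothing at hand accounts for this shift. From the compounds shown here alone, whether a methoxy group or a chlorine on that aryl ring would read like trifluoromethoxy stays open, as does the effect of an amine there.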